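The compounds below may be only part of what the source reports. "The series", "measured", "known", "first", "only" and "open" are said of these compounds alone.

Compound 1, whose structure is `CC(C)Nc1sc(C(=O)c2ccc(Cl)s2)c(N)c1C#N`, is the strongest of the three measured compounds in an assay for inhibition of Maternal embryonic leucine zipper kinase (Homo sapiens), read by ADP-Glo, with a stated time of 0.5 h (a higher number here means a weaker inhibitor, a lower number a stronger inhibitor), where compound 1 gives 192 nM. Its two neighbours each differ from it in a single place. Compound 2, `CC(C)Nc1sc(C(=O)c2cc(Cl)cs2)c(N)c1C#N`, carries a 4-chlorothiophen-2-yl in place of a 5-chlorothiophen-2-yl on the carbonyl carbon, and in this assay compound 2 gives 575 nM, so that the step of a 3.0-fold higher number from compound 1 to compound 2 (0.48 log units; beyond the scatter) is modest but beyond the scatter. Compound 3, `CC(C)Nc1sc(C(=O)c2ccc(Cl)s2)c(N)c1C(N)=O`, carries a carbamoyl in place of the cyano on an aromatic carbon, and compound 3 gives 388 nM, a step of a 2.0-fold higher number from compound 1 to compound 3 (0.31 log units; beyond the scatter), also modest and beyond the scatter.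

Compound 4, `N#Cc1c(NCc2ccccc2)sc(C(=O)c2ccc(Cl)s2)c1N`, is not yet measured. Its difference from compound 1 is benzyl in place of isopropyl on a nitrogen on an aromatic ring. Among the measured compounds shown here, neither measured step touches this nitrogen: one changes the chlorothiophene, the other the cyano group, so no measured step speaks directly to swapping isopropyl for benzyl. The two measured steps show that single changes elsewhere in this series move the number only modestly. The step from compound 1 to compound 4 is therefore expected to be a 1.3-fold higher number from compound 1 to compound 4 (0.11 log units; within the scatter), in either direction or none beyond the scatter. Compound 4 is estimated at 250 nM, within a range from 60 nM to 1000 nM.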

Compound 4, half-maximal inhibitory concentration: > 5000 nM
Compound 4: a limit, no number; the forecaster's own chance of this, stated with the estimate: 3%; middle value at least 20-fold (1.30 log units) from the limit.
By their numbers in this assay, from the lowest: compound 1; then compounds 3 and 2 (each within the scatter of the next). At a limit, above all of these: compound 4.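

In this assay compound 4 gives > 5000 nM, which is a limit of the assay and not a number: the limit of > 5000 nM in this assay, at which 1 of the 4 values shown sits. Even so, the limit is enough to fix a lower bound on the change, and an at least 26-fold higher number from compound 1 to compound 4 (1.41 log units; beyond the scatter) is a large step, whereas a 3.0-fold higher number from compound 1 to compound 2 (0.48 log units; beyond the scatter) and a 2.0-fold higher number from compound 1 to compound 3 (0.31 log units; beyond the scatter) were both modest. Among the places changed in these compounds, the nitrogen on an aromatic ring is therefore the one where a single swap, isopropylamino to benzylamino, weakens inhibition most, so this series does not tolerate every group at that position, something the changes to the chlorothiophene and the cyano group could not reveal.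

On these data alone, how far compound 4 lies past its limit stays unknown, and with only isopropyl and benzyl on this nitrogen, the data cannot separate the effect of the aromatic ring from that of the larger group as a whole. Open too, as far as these compounds go, is whether ethyl, cyclopropyl, cyclohexylmethyl or a longer chain such as n-butyl on the same nitrogen would stay close to compound 1 or fall away as compound 4 does.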